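Methyl for Cyclopentyl on a Ring Nitrogen

The source may hold more compounds than are shown below. What is called first, only, known or untested is meant among the compounds shown, and "the series" means these compounds.

Measured so far: compound 1 `Cc1nnc(S)n2c(C)nc(C)c12`, > 48000 nM; compound 2 `c1ncn2c(NC3CCCC3)nncc12`, > 48000 nM.

In a functional assay for inhibition, with Homo sapiens as the target (a lower number here means a stronger inhibitor, a higher number a weaker inhibitor), compound 1 gives > 48000 nM, which is a limit of the assay rather than a number. In this assay compound 2 likewise gives > 48000 nM, again a limit. Compound 2 thus sits at the limit of > 48000 nM in this assay, at which 2 of the 2 values shown sit. Compound 3 `CNc1nncc2cncn12` differs from compound 2 by methyl in place of cyclopentyl on a nitrogen on an aromatic ring. Among the compounds with values here, no measured step between compounds is at hand to guide the size of this change. Compound 3 is expected to remain near the limit, with the step that the limit leaves unreadable from compound 2 to compound 3 estimated as no change beyond the scatter. Compound 3 is estimated at 60000 nM, between 20000 nM and 200000 nM.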

Compound 3, half-maximal inhibitory concentration: > 48000 nM
Compound 3: no number, only a limit; the forecaster's own chance of this, stated with the estimate: 85%; the middle value is on the limit's open side.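

Within the data shown here, compound 2 and compound 3 both give only a limit in this assay, so no step between them can be read. The compounds shown leave open what methyl in place of cyclopentyl does to inhibition in this assay.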